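Iodo for Butyl in a Weakly Active Pair

The source may report more compounds than this note shows. Statements on the series, on what has been measured and on what is new or still open speak of the compounds shown alone.

Compound 1 `CCCCc1ccc([B-]2(c3ccccc3)[NH2+]CCO2)cc1`: 14300 nM
Compound 2 `OB(c1ccccc1)c1ccc(Cl)cc1`: 9700 nM

In an assay on HEK293 cells for inhibition of transient receptor potential cation channel subfamily V member 6 (Homo sapiens), read by FLIPR and calcium flux, with a stated time of 5 min (on this read-out higher numbers stand for weaker inhibition and lower numbers for stronger inhibition), compound 1 stands at 14300 nM, and compound 2 stands at 9700 nM; the two numbers lie within the usual scatter of each other, so neither can be ranked above the other. Compound 3 `Ic1ccc([B-]2(c3ccccc3)[NH2+]CCO2)cc1` differs from compound 1 by iodo in place of butyl on an aromatic carbon. Going by the values given here, no measured pair shows this change, so its size is not known from the data. On these two values alone, the step of a 1.3-fold lower number from compound 1 to compound 3 (0.11 log units; within the scatter) is expected to stay within the scatter, with no clear direction. Compound 3 is therefore estimated at 11000 nM, in the range 3500 nM to 35000 nM.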

Compound 3, half-maximal inhibitory concentration: 5400 nM
The estimate for compound 3 lay 2.0-fold (0.31 log units) above the measured number, and the stated range covers the measured number.
By their numbers in this assay, from the lowest: compounds 3, 2 and 1 (each within the scatter of the next, the first and the last beyond it).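

In this assay, iodo in place of butyl on an aromatic carbon, para to a large group, gives a 2.6-fold lower number from compound 1 to compound 3 (0.42 log units; beyond the scatter) and so marks this position as one where the substituent matters, if only modestly. Going by these compounds alone, the butyl chain is therefore not needed here for the inhibition seen, since the single iodo group serves better. Nothing measured here bears on why the number falls.

Going by these compounds, whether an amine, a carboxylic acid or a longer chain at this position would lower the number further remains open. So does whether the step would hold on another core.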